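The compounds below may be only part of what the source reports. "The series", "measured", "known", "first", "only" and "open" are said of these compounds alone.

In a physicochemical assay for solubility, in phosphate buffer, at pH 7.4 (on this read-out higher numbers stand for higher solubility and lower numbers for lower solubility), compound 1 `CC(C)Cn1cc(-c2ccnc3[nH]c(C4CCN(CC(=O)N(C)C)CC4)cc23)ccc1=O` gives 390000 nM and compound 2 `CN(C)C(=O)CN1CCC(c2cc3c(-c4ccc(=O)n(CCC5CCOCC5)c4)ccnc3[nH]2)CC1` gives 370000 nM. The step between them is a 1.1-fold lower number from compound 1 to compound 2 (0.02 log units; within the scatter). Compound 3 `CCn1cc(-c2ccnc3[nH]c(C4CCN(CC(=O)N(C)C)CC4)cc23)ccc1=O` gives > 1000000 nM, which is a limit of the assay and not a number. That places compound 3 at the limit of > 1000000 nM in this assay, at which 1 of the 3 values shown sits.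

Compound 4 `CN(C)C(=O)CN1CCC(c2cc3c(-c4ccc(=O)n(C5CCC5)c4)ccnc3[nH]2)CC1` has cyclobutyl in place of ethyl on an aromatic nitrogen. For the measured compounds named here, two measured steps bear on this change. Both alter the group on that same nitrogen and both end at the ethyl of compound 3. One is an at least 2.5-fold higher number from compound 1 to compound 3 (0.40 log units; beyond the scatter), and the other is an at least 2.7-fold higher number from compound 2 to compound 3 (0.43 log units; beyond the scatter). Both sizes are only bounds, since one end of each is a limit. Read in reverse, they show compound 1 and compound 2, with their larger groups, sitting lower than compound 3. A modest or somewhat larger fall in the number is therefore expected, and the estimated step is an at least 2.2-fold lower number from compound 3 to compound 4 (0.34 log units; beyond the scatter). Compound 4 is expected at about 450000 nM, with an estimated range from 200000 nM to 1000000 nM.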

Compound 4, solubility: > 1000000 nM
Compound 4: a limit, no number; the forecaster's own chance of this, stated with the estimate: 20%; middle value at least 2.2-fold (0.34 log units) from the limit.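

In this assay, the value of compound 4 is a limit of the assay and not a number. Even so, cyclobutyl on this aromatic nitrogen stands clear of the two other groups compared here, with an at least 2.7-fold higher number from compound 2 to compound 4 (0.43 log units; beyond the scatter) and an at least 2.5-fold higher number from compound 1 to compound 4 (0.40 log units; beyond the scatter). The earlier compounds shown here showed only groups larger than ethyl sitting lower than ethyl, and compound 4 goes against that pattern: with 4 heavy atoms in place of 2, it still reaches the limit.

From the compounds shown here alone, whether cyclobutyl or ethyl gives the higher number stays open, and the step between compound 3 and compound 4 cannot be read because both sit at the same limit: the limit of > 1000000 nM in this assay, at which 2 of the 4 values shown sit. Going by these compounds, it also remains open how this nitrogen would respond to a group carrying an amine or a carboxylic acid.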